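A Small Swap at a Starting Point Near the Floor

The source may report more compounds than this note shows. Statements on the series, on what has been measured and on what is new or still open speak of the compounds shown alone.

Of the compounds shown here, two have so far been tested in a functional assay on the whole organism for inhibition, with Rattus norvegicus as the target, with stated times of 1 h and 3.5 h, at a dose of 100 mg/kg by the oral route; a higher number here means more inhibition at the dose given (going by the name of the read-out), a lower number less inhibition. Compound 1 `CC(C)(C)c1nc(NC(N)=O)ncc1-c1ccccc1` gives 14%. Compound 2 `CC(C)(C)c1ccnc(Cl)n1` shows only a limit of the assay in this assay, < 5%. Compound 2 thus stands at the limit of < 5% in this assay, at which 1 of the 2 values shown sits. Compound 3 `CSc1nccc(C(C)(C)C)n1` is compound 2 with a single change: methylsulfanyl in place of chloro on an aromatic carbon. No measured step joins two of these compounds, so the comparison has no precedent. With compound 2 resting at a limit, the step of a number no lower from compound 2 to compound 3 (the limit leaves the size open) is expected to be none beyond the scatter. Compound 3 is therefore estimated at 5%, within 0% to 15%.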

Compound 3, a percentage reported as inhibition, in the whole organism at one dose (the size of the read-out at that dose, not a potency): 35%
Compound 3: middle estimate off by 30 percentage points, on the low side; measured number above the stated range.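

On the aromatic carbon between two ring nitrogen atoms, methylsulfanyl in place of chloro gives a number at least 30 percentage points higher from compound 2 to compound 3 (beyond the scatter) in this assay. Going by these compounds alone, this position therefore responds to what sits on it, which the earlier compounds could not show. Compound 2 stands at a limit of the assay rather than a number, so the true size of the step stays open: the limit of < 5% in this assay, at which 1 of the 3 values shown sits.

Going by these compounds, whether the sulfur or its added methyl carbon matters more remains unknown. So does how an amine, a methoxy group or a longer chain such as ethylsulfanyl would fare here.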